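Furan-3-yl for ethynyl on the nucleoside core

The source may report more compounds than this note shows. Statements on the series, on what has been measured and on what is new or still open speak of the compounds shown alone.

Compound 1 `C#Cc1cn([C@@H]2O[C@H](CO)[C@@H](O)[C@H]2O)c2ncnc(C)c12`: 19200 nM
Compound 2 `C#Cc1cn([C@@H]2O[C@H](CO)[C@@H](O)[C@H]2O)c2ncnc(N(C)C)c12`: 390 nM
Compound 3 `Cc1nc(N)c2c(-c3ccco3)cn([C@@H]3O[C@H](CO)[C@@H](O)[C@H]3O)c2n1`: > 20000 nM

All numbers come from a functional assay on A549 cells (Homo sapiens), read by MTT assay, with a stated time of 72 h; a lower number here means a stronger inhibitor, a higher number a weaker inhibitor. Compound 1 stands at the highest of the two numbers that are numbers; the nearest is compound 2, reached by a 49-fold lower number from compound 1 to compound 2 (1.69 log units; beyond the scatter), dimethylamino in place of methyl on an aromatic carbon. The value of compound 3 is only a limit of the measurement, (the limit of > 20000 nM in this assay, at which 1 of the 3 values shown sits).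

Compound 4 `Cc1ncnc2c1c(-c1ccoc1)cn2[C@@H]1O[C@H](CO)[C@@H](O)[C@H]1O` is the not yet measured member. It differs from compound 1 by furan-3-yl in place of ethynyl on an aromatic carbon. For the measured compounds named here, no measured step changes this position, so the single step that exists, that from compound 1 to compound 2, changes another place and bears on the present change only indirectly. Going by the values given here, compound 3 carries a furan ring on the same core together with other changes and reaches only the limit, which gives no size for the step.

With compound 1 already weak, the expected step of a 1.3-fold higher number from compound 1 to compound 4 (0.11 log units; within the scatter) is none beyond the scatter, leaning to a weaker number. Compound 4 is therefore estimated at 25000 nM, within 7000 nM to 90000 nM, with a fair chance that only a limit is reported.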

Compound 4, half-maximal inhibitory concentration: > 20000 nM
Compound 4 gave a limit, no number; the forecaster's own chance of this, stated with the estimate: 50%; the middle value is on the limit's open side.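

The change from ethynyl to furan-3-yl at this position can now be read directly on the core of compound 1, and the step is an at least 1.0-fold higher number from compound 1 to compound 4 (0.01 log units; that floor lies within the scatter). In this assay compound 4 gives > 20000 nM, which is a limit and not a number. The step is therefore only a floor: it shows no gain from furan-3-yl in this pair, but it cannot separate a change within the scatter from a much larger loss. Compound 1 at 19200 nM leaves little room for a loss to be read on this core. The measurable range now ends for two of the compounds shown: the limit of > 20000 nM in this assay, at which 2 of the 4 values shown sit.

As far as these compounds go, what the same change does on the dimethylamino core of compound 2, which at 390 nM would leave room for a step to be read in either direction, remains open. Also open, from the compounds shown here alone, is how a nitrile, an amine or a longer chain such as propyl would read at this position in place of ethynyl.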